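The source may report more compounds than this note shows. Statements on the series, on what has been measured and on what is new or still open speak of the compounds shown alone.

Compound 1 `COC(=O)N1CCCc2cc(S(=O)(=O)N3CC(c4ccccc4)NC3=O)ccc21`: 16500 nM in a functional assay on cells (KATO III cell, Homo sapiens) for antiproliferative activity, read by MTT assay; a higher number here means a weaker inhibitor, a lower number a stronger inhibitor
Compound 2 `C=CCOC(=O)N1CCCc2cc(S(=O)(=O)N3CC(c4ccccc4)NC3=O)ccc21`: 5050 nM
Compound 3 `O=C(OCCCl)N1CCCc2cc(S(=O)(=O)N3CC(c4ccccc4)NC3=O)ccc21`: 8680 nM

Compound 1 gives the highest of the three numbers. The step of a 3.3-fold lower number from compound 1 to compound 2 (0.51 log units; beyond the scatter) is a modest one, while the step of a 1.9-fold lower number from compound 1 to compound 3 (0.28 log units; within the scatter) stays within the scatter. Both of these steps add a group on the saturated chain carbon bound to the oxygen that sits on the carbonyl group, and leave that oxygen in place.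

Compound 4 `NC(=O)N1CCCc2cc(S(=O)(=O)N3CC(c4ccccc4)NC3=O)ccc21` differs from compound 1 in another way: amino in place of methoxy on a carbonyl carbon. Read one bond further out, methoxycarbonyl becomes carbamoyl, so the oxygen itself is exchanged for a nitrogen. Among the compounds with values here, no measured step touches this position, so the two steps from compound 1 can only show that changes at the carbamate end moved the numbers by a small amount in one direction. With no direct comparison, the expected step of a 1.1-fold higher number from compound 1 to compound 4 (0.04 log units; within the scatter) is no change beyond the scatter. Compound 4 is therefore expected to give about 18000 nM, with a range from 7000 nM to 50000 nM.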

Compound 4, half-maximal inhibitory concentration: 3590 nM
Beside the measured number, compound 4's estimate is 5.0-fold (0.70 log units) above it, outside the stated range (below it).
By their numbers in this assay, from the lowest: compounds 4, 2, 3 and 1 (each within the scatter of the next, the first and the last beyond it).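

The earlier compounds shown here all kept an oxygen on the carbonyl carbon and varied only the chain beyond it, so only this result in this assay shows what happens when that oxygen is exchanged for a nitrogen. Amino in place of methoxy gives a 4.6-fold lower number from compound 1 to compound 4 (0.66 log units; beyond the scatter) and so shows that neither the oxygen nor a carbon chain on it is needed to keep this activity. Amino in place of 2-chloroethoxy gives a 2.4-fold lower number from compound 3 to compound 4 (0.38 log units; beyond the scatter) as well, yet amino in place of allyloxy gives a 1.4-fold lower number from compound 2 to compound 4 (0.15 log units; within the scatter) and so does not separate those two groups.

A methylamino or dimethylamino group on the same carbonyl carbon would test whether the amino hydrogens count, and a plain methyl group there would test whether any oxygen or nitrogen is needed at all. No measurement shown gives a reason for any of these steps.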